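Tetrahydroisoquinolin-2-yl for 2-chlorophenyl on the sulfonyl sulfur

The source may report more compounds than this note shows. Statements on the series, on what has been measured and on what is new or still open speak of the compounds shown alone.

Measured so far:
compound 1 `O=C(NCc1ccncc1)Nc1ccc(S(=O)(=O)c2ccccc2Cl)cc1` — 79 nM
compound 2 `CCOC(=O)c1ccc(NC(=O)NCc2cc[nH]n2)cc1` — 69000 nM

In an assay on isolated protein for activation of Nicotinamide phosphoribosyltransferase (Homo sapiens) (on this read-out higher numbers stand for an effect only at larger amounts of compound and lower numbers for an effect already at smaller amounts), compound 1 gives 79 nM, the lowest of the two numbers in hand. Among the measured compounds shown here, the only other compound, compound 2, gives 69000 nM in this assay, a gap far beyond the usual scatter; compound 2 differs from compound 1 at more than one place, so no single-point step can be read from the pair, and the two values are simply recorded side by side.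

Compound 3 `O=C(NCc1ccncc1)Nc1ccc(S(=O)(=O)N2CCc3ccccc3C2)cc1` is the next compound for this assay. Relative to compound 1 the change is 1,2,3,4-tetrahydroisoquinolin-2-yl in place of 2-chlorophenyl on a sulfonyl sulfur. For the measured compounds named here, no measured pair in the set isolates this kind of replacement, so the expectation rests on compound 1 alone.

The replacement is expected to move the number by a modest amount, most likely upward, with the step from compound 1 to compound 3 estimated at a 2.5-fold higher number from compound 1 to compound 3 (0.40 log units; beyond the scatter). For compound 3 the estimated value in this assay is 200 nM, with a range from 40 nM to 1500 nM.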

Compound 3, half-maximal effective concentration: 142 nM
Compound 3: the middle estimate sits 1.4-fold (0.15 log units) above what was measured; measured number inside the range.
By their numbers in this assay, from the lowest: compounds 1 and 3 (each within the scatter of the next); then compound 2.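

In this assay, the step to 1,2,3,4-tetrahydroisoquinolin-2-yl in place of 2-chlorophenyl on a sulfonyl sulfur is a 1.8-fold higher number from compound 1 to compound 3 (0.25 log units; within the scatter), so the two compounds cannot be told apart on this read-out. Among the compounds shown here, this is the first single-place comparison, and it shows that a number of this order does not depend on 2-chlorophenyl at this position: the chlorine leaves, a nitrogen now sits on the sulfonyl sulfur in place of an aromatic carbon, and a six-membered non-aromatic ring enters alongside the aromatic ring. No measurement at hand accounts for the two groups reading alike.

Open, on these data alone, is how much of the entering group is needed, since a piperidin-1-yl or morpholin-4-yl group on the same sulfur would show whether the aromatic ring of 1,2,3,4-tetrahydroisoquinolin-2-yl contributes to the read-out. On the other side of the comparison, a plain phenyl group at this position would separate the contribution of the chlorine from that of the aromatic ring in 2-chlorophenyl.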